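Second chloro on the aryl ring of compound 2

The source may hold more compounds than are shown below. What is called first, only, known or untested is meant among the compounds shown, and "the series" means these compounds.

The series shares the core seen in compound 1 `COc1cc(-n2c(-c3ccc(F)cc3)csc2=S)cc(OC)c1OC` and compound 2 `COc1cc(-n2c(-c3ccc(Cl)cc3)csc2=S)cc(OC)c1OC`. In a functional assay on T47D cells (Homo sapiens) for cytotoxicity, read by MTT assay, with a stated time of 48 h (a higher number here means a weaker inhibitor, a lower number a stronger inhibitor), compound 1 gives 38.9 ug/mL. In this assay compound 2 gives > 100 ug/mL, a limit of the assay rather than a number. Compound 2 thus stands at the weak end of the two measured values, as recorded by the limit of > 100 ug/mL in this assay, at which 1 of the 2 values shown sits. Within the data shown here, the one measured step, an at least 2.5-fold higher number from compound 1 to compound 2 (0.41 log units; beyond the scatter), runs toward weaker inhibition. Compound 3 `COc1cc(-n2c(-c3ccc(Cl)cc3Cl)csc2=S)cc(OC)c1OC` differs from compound 2 as follows: chloro in place of hydrogen on an aromatic carbon. Among the measured compounds shown here, no measured step covers a chloro in place of hydrogen, so only the direction of that single step is at hand, and it gives no ground to expect a return to the range of compound 1. A step that the limit leaves unreadable from compound 2 to compound 3 is expected, meaning no movement beyond the scatter. Compound 3 is expected to give 110 ug/mL, within 40 ug/mL to 300 ug/mL, most likely again reported as a limit.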

Compound 3, half-maximal inhibitory concentration: 43.4 ug/mL
The estimate for compound 3 lay 2.5-fold (0.40 log units) above the measured number; the range from low to high includes it.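

Among these compounds, the change from 4-chlorophenyl to 2,4-dichlorophenyl brings an at least 2.3-fold lower number from compound 2 to compound 3 (0.36 log units; beyond the scatter) in this assay, so chloro in place of hydrogen at this position, ortho to a large group, runs toward stronger inhibition, opposite to the one earlier step. Compound 2 is recorded only as a limit of the assay and not as a number: the limit of > 100 ug/mL in this assay, at which 1 of the 3 values shown sits. The 4-chloro group therefore does not hold the series at the weak end, and a 1.1-fold higher number from compound 1 to compound 3 (0.05 log units; within the scatter) leaves 2,4-dichlorophenyl and 4-fluorophenyl unseparated.

Open, on these data alone, is whether an amine or a carboxylic acid ortho to the same large group would move the reading as chloro does. Also open, as far as these compounds go, is how the 4-fluorophenyl ring of compound 1 would respond to the same added chloro group.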